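Chloro in place of nitro on an aromatic carbon

The source may report more compounds than this note shows. Statements on the series, on what has been measured and on what is new or still open speak of the compounds shown alone.

Compound 1 `C/C(=N/NC(=S)Nc1ccccc1F)c1ccccn1`: 5 nM
Compound 2 `C/C(=N/NC(=S)Nc1ccccc1[N+](=O)[O-])c1ccccn1`: 4.3 nM
Compound 3 `C/C(=N/NC(=S)Nc1ccccc1Cl)c1ccccn1`: not yet measured

In a functional assay on U-87MG ATCC cells (Homo sapiens) for cytotoxicity, read by MTT assay, with a stated time of 48 h (a lower number here means a stronger inhibitor, a higher number a weaker inhibitor), compound 2 gives 4.3 nM. Going by the values given here, it stands within the scatter of the only other measured compound, compound 1, at 5 nM, so neither can be ranked above the other.

Compound 3 differs from compound 2 at one place: chloro in place of nitro on an aromatic carbon. In words, this is chloro in place of nitro on an aromatic carbon, ortho to a large group.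

Among the compounds with values here, only one measured step bears on this change, nitro in place of fluoro on an aromatic carbon: a 1.2-fold lower number from compound 1 to compound 2 (0.07 log units; within the scatter). Within the data shown here, that step is small, but it is a single comparison, and no measurement yet shows what chloro does. On the evidence of compound 2 at 4.3 nM and that one step, no change beyond the scatter is expected in this assay. The expected change is a 1.2-fold higher number from compound 2 to compound 3 (0.07 log units; within the scatter). For compound 3 the estimated value is 5 nM, with an expected range of 2.2 nM to 12 nM.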

Compound 3, half-maximal inhibitory concentration: 2.6 nM
For compound 3 the middle estimate is 1.9-fold (0.28 log units) above the measured one, and the stated range covers the measured number.
By their numbers in this assay, from the lowest: compounds 3, 2 and 1 (each within the scatter of the next).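

In this assay, chloro, on an aromatic carbon ortho to a large group, is a third group at this place that gives no step beyond the scatter: chloro in place of nitro gives a 1.7-fold lower number from compound 2 to compound 3 (0.22 log units; within the scatter), and chloro in place of fluoro gives a 1.9-fold lower number from compound 1 to compound 3 (0.28 log units; within the scatter). The change from nitro to chloro is also a larger change in the group itself than its step shows, since 3 heavy atoms with 2 hydrogen-bond acceptors leave and 1 heavy atom with 0 hydrogen-bond acceptors enters, yet compound 2 and compound 3 cannot be ranked. No measurement is available that would explain why these three compounds cannot be separated.

The compounds shown leave open whether a group of another kind at this place, such as an amine, a carboxylic acid or a longer chain, would give a step beyond the scatter. They also leave open whether fluoro, nitro and chloro would stay within the scatter of one another at any other place on the shared core.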